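Aryl variation on the shared core: expectation for compound 4

The source may report more compounds than this note shows. Statements on the series, on what has been measured and on what is new or still open speak of the compounds shown alone.

Three compounds share one core and differ only in the aryl group on an aromatic carbon of the five-membered ring. In a functional assay on BJAB cells (Homo sapiens) for antiproliferative activity, with a stated time of 4 days (a lower number here means that less compound is needed, a higher number that more compound is needed for the effect), compound 1 `Cc1nn(-c2nc(-c3ccc(Cl)c(Cl)c3)c(SC(C)C)s2)c(C(=O)O)c1-c1ccncc1` gives 5900 nM. Compound 2 `Cc1nn(-c2nc(-c3ccc(Cl)c(Cl)c3)c(SC(C)C)s2)c(C(=O)O)c1-c1cccc(C(F)(F)F)c1` gives 22000 nM in this assay, and compound 3 `Cc1nn(-c2nc(-c3ccc(Cl)c(Cl)c3)c(SC(C)C)s2)c(C(=O)O)c1-c1cccc(F)c1` gives 900 nM. Compound 3 therefore stands lowest of the three: its nearest neighbour is compound 1, with a 6.6-fold lower number from compound 1 to compound 3 (0.82 log units; beyond the scatter), and its furthest is compound 2, with a 24-fold lower number from compound 2 to compound 3 (1.39 log units; beyond the scatter). The step of a 3.7-fold higher number from compound 1 to compound 2 (0.57 log units; beyond the scatter) sits between those two.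

Compound 4 `Cc1cc(C)cc(-c2c(C)nn(-c3nc(-c4ccc(Cl)c(Cl)c4)c(SC(C)C)s3)c2C(=O)O)c1` is not yet measured. Relative to compound 3 it carries 3,5-dimethylphenyl in place of 3-fluorophenyl on an aromatic carbon.

The bearing steps are the two that end at compound 3. Both exchanges of the aryl group toward 3-fluorophenyl brought the number down, and the exchange of trifluoromethyl for fluoro in a 24-fold lower number from compound 2 to compound 3 (1.39 log units; beyond the scatter) was the largest step seen. 3,5-Dimethylphenyl adds two methyl groups and removes the fluorine, which runs against the direction of those steps, so a modest rise beyond the scatter is expected rather than a further drop. Compound 4 is estimated at 3000 nM, in the range 900 nM to 12000 nM, which is an expected step of a 3.3-fold higher number from compound 3 to compound 4 (0.52 log units; beyond the scatter).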

Compound 4, half-maximal effective concentration: 2700 nM
Estimate against measurement, compound 4: 1.1-fold (0.05 log units) above; low and high end bracket the measured number.
By their numbers in this assay, from the lowest: compound 3; then compound 4; then compound 1; then compound 2.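

In this assay, the new aryl group gives a mixed picture at this position on the five-membered ring: a 3.0-fold higher number from compound 3 to compound 4 (0.48 log units; beyond the scatter), while an 8.1-fold lower number from compound 2 to compound 4 (0.91 log units; beyond the scatter) and a 2.2-fold lower number from compound 1 to compound 4 (0.34 log units; beyond the scatter). Moving from 3-fluorophenyl to 3,5-dimethylphenyl therefore raises the number, but compound 4 does not reach the level of compound 2, so a phenyl group with two substituents is compatible with a number below those of compound 1 and compound 2. The all-carbon aryl groups also now fall on both sides of pyridin-4-yl, with compound 3 and compound 4 below compound 1 and compound 2 above it, and nothing at hand explains these differences.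

As far as these compounds go, it remains open whether a single methyl group on the phenyl ring would stand closer to compound 3 or to compound 4, and whether two fluoro groups would follow the 3-fluorophenyl or the 3,5-dimethylphenyl result. From the compounds shown here alone, how a hydroxy group, an amine or a methoxy group on the phenyl ring would place in this order also remains open.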